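The source may report more compounds than this note shows. Statements on the series, on what has been measured and on what is new or still open speak of the compounds shown alone.

Measured so far in a functional assay on SK-OV-3 cells (Homo sapiens) for cytotoxicity; a lower number here means that less compound is needed, a higher number that more compound is needed for the effect:
- compound 1 `COC(=O)[C@H](O)C/C(C)=C\CC[C@H](C)/C=C/C=C(\C)CCCC1=CC(=O)O[C@H]1O`: > 30 ug/mL, a limit
- compound 2 `CC(=O)C(O)C(O)C/C(C)=C\CC[C@H](C)/C=C/C=C(\C)CCCC1=CC(=O)OC1O`: 14.9 ug/mL
- compound 3 `COC1C=C(CCC/C(C)=C/C=C/[C@@H](C)CC/C=C(/C)C[C@H]2OC(=O)C(C)=C2O)C(=O)O1`: > 30 ug/mL, a limit

Most of this small set sits at the limit of > 30 ug/mL in this assay, at which 2 of the 3 values shown sit. Compound 3 stands at that ceiling, and its > 30 ug/mL is a limit and not a number. Compound 4 `CC1=C(O)[C@@H](C/C(C)=C\CC[C@H](C)/C=C/C=C(\C)CCCC2=CCN(CC(=O)O)C2=O)OC1=O` differs from compound 3 by one change: a group of 10 heavy atoms (6 carbon, 1 nitrogen, 3 oxygen; one five-membered non-aromatic ring with 1 hetero atom) in place of a group of 8 heavy atoms (5 carbon, 3 oxygen; one five-membered non-aromatic ring with 1 hetero atom), on a saturated chain carbon, three bonds along the chain from a double-bonded chain carbon. Among the measured compounds shown here, no measured step shows what such a change does. For the measured compounds named here, compound 2, at 14.9 ug/mL, gives the only number in the set, and it suggests that a measurable value is possible. A small step toward less compound needed is expected, an at least 1.2-fold lower number from compound 3 to compound 4 (0.07 log units; that floor lies within the scatter), and it may stay within the scatter. Compound 4 is estimated at 25 ug/mL, with an expected range from 10 ug/mL to 50 ug/mL.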

Compound 4, concentration for half-maximal effect: > 30 ug/mL
Compound 4 gave a limit, no number (the forecaster's own chance of this, stated with the estimate: 50%); at least 1.2-fold (0.07 log units) between middle value and limit.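

Compound 3 and compound 4 both give only a limit and not a number, so no step between them can be read: the limit of > 30 ug/mL in this assay, at which 3 of the 4 values shown sit.

On these data alone, whether exchanging the group of 8 heavy atoms for the group of 10 heavy atoms changes the amount of compound needed remains open.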